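From 3-(methylsulfanyl)phenyl to 2,3-dihydro-1H-inden-5-yl on the shared core

The source may report more compounds than this note shows. Statements on the series, on what has been measured and on what is new or still open speak of the compounds shown alone.

In a functional assay (aorta) with Rattus norvegicus as the target (on this read-out lower numbers stand for stronger inhibition and higher numbers for weaker inhibition), compound 1 (`CC1(C)Oc2ccc(C#N)cc2[C@@H](/N=C(\NC#N)Nc2ccccc2)[C@@H]1O`) gives 1400 nM; 1300 nM (2 entries), as its repeated entries show (the several entries of compound 1 in this assay, 1400 nM; 1300 nM (2 entries)). For the measured compounds named here, compound 2 (`CSc1cccc(N/C(=N/[C@@H]2c3cc(C#N)ccc3OC(C)(C)[C@H]2O)NC#N)c1`) gives 1400 nM, its only numerical value in this assay, and one further entry carries no single number. The values of these two compounds lie within the scatter of each other.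

Compound 3 (`CC1(C)Oc2ccc(C#N)cc2[C@@H](/N=C(\NC#N)Nc2ccc3c(c2)CCC3)[C@@H]1O`) has not yet been measured. The structural change from compound 2 is 2,3-dihydro-1H-inden-5-yl in place of 3-(methylsulfanyl)phenyl on an amine nitrogen.

Going by the values given here, no measured step tests this replacement directly. With compound 1 at 1400 nM; 1300 nM (2 entries) and compound 2 at 1400 nM, no step beyond the scatter is expected in this assay, and neither direction is favoured. The estimated step is a 1.2-fold lower number from compound 2 to compound 3 (0.07 log units; within the scatter). For compound 3 the expected value is 1200 nM, with an estimated range of 400 nM to 3500 nM.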

Compound 3, half-maximal inhibitory concentration: 41300 nM
For compound 3 the middle estimate is 34-fold (1.54 log units) below the measured one; the whole stated range lies below it.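

The aryl group on the amine nitrogen is not a free choice in this assay: 2,3-dihydro-1H-inden-5-yl in place of 3-(methylsulfanyl)phenyl gives a 30-fold higher number from compound 2 to compound 3 (1.47 log units; beyond the scatter). Compound 1 at 1400 nM; 1300 nM (2 entries) and compound 2 at 1400 nM lie within the scatter of each other, so this position looked tolerant of change, whereas compound 3 now shows that this tolerance does not extend to every group. The step is far wider than the spread of the repeated measurements: the several entries of compound 1 in this assay, 1400 nM; 1300 nM (2 entries)

On these data alone, whether the weaker inhibition follows from the fused five-membered ring or from another feature of the new group remains open. A dimethylphenyl or a naphthyl group on the same nitrogen would help show how far the effect extends to other ring patterns.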